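This account rests on a few compounds, and the source may have more. Where it says the series, first, only, none or still open, it means among the compounds named here.

Compound 1 `N#CC1=C(N)N(c2ccc(S(N)(=O)=O)cc2)C2=C(C(=O)CCC2)C1c1ccc(Cl)cc1Cl` gives 40% in a functional assay on Ehrlich cells (Mus musculus) for cytotoxicity, read by trypan blue exclusion, with a stated time of 2 h, tested at 10 ug/mL; a higher number here means a stronger effect of the compound at the concentration tested, a lower number a weaker effect. For the measured compounds named here, compound 2 `C=CCNC(=S)NC1=C(C#N)C(c2ccc(Cl)cc2Cl)C2=C(CCCC2=O)N1c1ccc(S(N)(=O)=O)cc1` gives 10% in this assay, the lowest of the two numbers, with compound 1 as its only neighbour. Going by the values given here, the single measured step, a number 30 percentage points lower from compound 1 to compound 2 (beyond the scatter), concerns a different change, a large group in place of a hydrogen atom, so it does not speak to the swap that follows. Compound 3 `N#CC1=C(NC(=S)Nc2ccccc2)N(c2ccc(S(N)(=O)=O)cc2)C2=C(C(=O)CCC2)C1c1ccc(Cl)cc1Cl` differs from compound 2 by phenyl in place of allyl on an amide-type nitrogen. Among the compounds with values here, with no measured step bearing on this change, the expected step is a number 5 percentage points higher from compound 2 to compound 3 (within the scatter), nothing beyond the scatter. Compound 3 is therefore estimated at 15%, between 0% and 40%.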

Compound 3, a percentage reported as activity, at one concentration (the size of the read-out at that concentration, not a potency): 40%
The estimate for compound 3 lay 25 percentage points below the measured number; the range from low to high includes it.
By their numbers in this assay, from the lowest: compound 2; then compounds 1 and 3 (each within the scatter of the next).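

In this assay, phenyl in place of allyl on an amide-type nitrogen gives a number 30 percentage points higher from compound 2 to compound 3 (beyond the scatter) and so shows that the end of this added group counts, not just its presence. The whole phenyl-bearing group in place of a hydrogen atom gives no change at the digits printed from compound 1 to compound 3 (within the scatter) and so shows that a group this large on the amine nitrogen need not lower the number. No measurement at hand explains the difference between allyl and phenyl. On these data alone, whether a saturated chain such as propyl would read like allyl or like phenyl stays open, as does the effect of a benzyl group or a pyridyl ring.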